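Swapping the ring on the ether oxygen of compound 1

The source may hold more compounds than are shown below. What is called first, only, known or untested is meant among the compounds shown, and "the series" means these compounds.

Compound 1 `CCS(=O)(=O)N1CC(Oc2cncc(N3C(=O)c4ccc(Cl)cc4C3(C)C)c2)C1` gives 4 nM in an assay on cells for inhibition of cytochrome P450 11B2, mitochondrial (Homo sapiens), read by HTRF (on this read-out higher numbers stand for weaker inhibition and lower numbers for stronger inhibition), the second highest of the three numbers shown. Compound 2 `CC1(C)c2cc(Cl)ccc2C(=O)N1c1cncc(OC2CN(C(=O)c3ncccc3Cl)C2)c1` gives 5 nM, and compound 3 `Cn1cc(C(=O)N2CC(Oc3cncc(N4C(=O)c5ccc(Cl)cc5C4(C)C)c3)C2)cn1` gives 0.5 nM. Compound 4 `CC(=O)N1CC[C@@H](Oc2cncc(N3C(=O)c4ccc(Cl)cc4C3(C)C)c2)C1` differs from compound 1 by a group of 8 heavy atoms (6 carbon, 1 nitrogen, 1 oxygen; one five-membered non-aromatic ring with 1 hetero atom) in place of a group of 9 heavy atoms (5 carbon, 1 nitrogen, 2 oxygen, 1 sulfur; one four-membered non-aromatic ring with 1 hetero atom), on an oxygen on an aromatic ring. The measured steps all alter the group on the ring nitrogen instead: a 1.3-fold higher number from compound 1 to compound 2 (0.10 log units; within the scatter) and an 8.0-fold lower number from compound 1 to compound 3 (0.90 log units; beyond the scatter). Among the measured compounds shown here, those changes left the number unchanged or lowered it modestly, and no measured pair tests a change of the ring itself. Little movement beyond the scatter is therefore expected, so the estimate is a 1.3-fold higher number from compound 1 to compound 4 (0.10 log units; within the scatter). Compound 4 is expected to give about 5 nM, within a range from 1.5 nM to 15 nM.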

Compound 4, half-maximal inhibitory concentration: 11 nM
Compound 4: middle estimate off by 2.2-fold (0.34 log units), on the low side, within the range that was stated.
By their numbers in this assay, from the lowest: compound 3; then compounds 1 and 2 (each within the scatter of the next); then compound 4.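

In this assay the group on the oxygen gives a 2.8-fold higher number from compound 1 to compound 4 (0.44 log units; beyond the scatter) and so shows the first rise beyond the scatter in this series, meaning weaker inhibition. This step replaces the four-membered ring with a five-membered one and ethylsulfonyl with acetyl together, so the rise cannot be assigned to either change alone. No measurement shown gives a cause for this rise.

Still open, from the compounds shown here alone, is what 1-acetylazetidin-3-yl would give on the same oxygen, which would separate ring size from the acetyl group. Going by these compounds, the mirror-image form of 1-acetylpyrrolidin-3-yl also remains open.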